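The source may report more compounds than this note shows. Statements on the series, on what has been measured and on what is new or still open speak of the compounds shown alone.

- compound 1 `CN1CCC(NS(=O)(=O)c2ccccc2Nc2cc(-c3ccc4ccn(C)c4c3)c3nccnc3c2)C1`: 0.667 h
- compound 2 `CN(Cc1cncnc1)S(=O)(=O)c1ccccc1Nc1cc(-c2ccc3ccn(C)c3c2)c2nccnc2c1`: 0.2 h

In an ADME assay on microsomes from liver (Mus musculus, strain CD-1) for metabolic stability, read by LC-MS, tested at 2 uM (on this read-out lower numbers stand for a shorter-lived compound and higher numbers for a longer-lived compound), compound 2 has the lower of the two numbers, 0.2 h. Compound 3 `Cn1ccc2ccc(-c3cc(Nc4ccccc4S(=O)(=O)NCC4CCOCC4)cc4nccnc34)cc21` has not yet been measured. It differs from compound 2 as follows: ((oxan-4-yl)methyl)amino in place of methyl((pyrimidin-5-yl)methyl)amino on a sulfonyl sulfur. In words, ((oxan-4-yl)methyl)amino stands in place of methyl((pyrimidin-5-yl)methyl)amino on a sulfonyl sulfur.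

For the measured compounds named here, only one measured step bears on this change: a 3.3-fold lower number from compound 1 to compound 2 (0.52 log units; beyond the scatter). That step brought in the same group that now leaves, so a move back towards compound 1 at 0.667 h is expected. Going by the values given here, no measured compound carries the entering group, so a full return cannot be assumed. The expected change is a 2.0-fold higher number from compound 2 to compound 3 (0.30 log units; within the scatter), which is modest. For compound 3 the estimate is 0.4 h, with an expected range of 0.15 h to 1 h.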

Compound 3, half-life: 0.3 h
Compound 3: the middle estimate sits 1.3-fold (0.12 log units) above what was measured; low and high end bracket the measured number.
By their numbers in this assay, from the lowest: compounds 2 and 3 (each within the scatter of the next); then compound 1.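

In this assay, ((oxan-4-yl)methyl)amino in place of methyl((pyrimidin-5-yl)methyl)amino on the sulfonyl sulfur leaves compound 2 and compound 3 within the scatter of each other (a 1.5-fold higher number from compound 2 to compound 3 (0.18 log units; within the scatter)), even though an aromatic ring gives way to a non-aromatic one and the sulfonamide nitrogen regains its hydrogen. Compared with compound 1, (oxan-4-yl)methyl in place of 1-methylpyrrolidin-3-yl on the sulfonamide nitrogen gives a step beyond the scatter (a 2.2-fold lower number from compound 1 to compound 3 (0.35 log units; beyond the scatter)), so two different groups now fall short of compound 1. Nothing available here explains these differences.

Going by these compounds, whether the ring nitrogen of 1-methylpyrrolidin-3-yl matters for the longer half-life of compound 1 remains open. A 2-(dimethylamino)ethyl chain on the sulfonamide nitrogen would help test this, since it carries an amine without the ring.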